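Replacing the 4-cyanophenyl of compound 3 with 1H-pyrazol-4-yl

The source may hold more compounds than are shown below. What is called first, only, known or untested is meant among the compounds shown, and "the series" means these compounds.

Compound 1 `O=c1nc(-c2ccccc2)c2cc(-c3ccccc3)ccc2[nH]1`: > 50000 nM (a limit)
Compound 2 `O=c1nc(-c2ccccc2)c2cc(-c3ccccc3F)ccc2[nH]1`: 50000 nM
Compound 3 `N#Cc1ccc(-c2ccc3[nH]c(=O)nc(-c4ccccc4)c3c2)cc1`: > 50000 nM (a limit)

In an ADME assay on THP-1 cells (Homo sapiens) for cytotoxicity, read by MTT assay, with a stated time of 72 h (a higher number here means that more compound is needed for the effect, a lower number that less compound is needed), compound 3 stands only at a limit of > 50000 nM. The readings gather at the limit of > 50000 nM in this assay, at which 2 of the 3 values shown sit. Compound 4 `O=c1nc(-c2ccccc2)c2cc(-c3cn[nH]c3)ccc2[nH]1` carries 1H-pyrazol-4-yl in place of 4-cyanophenyl on an aromatic carbon. Three measured steps change this same substituent: a number no higher from compound 1 to compound 2 (the limit leaves the size open), a step that the two limits leave unreadable from compound 1 to compound 3 and a number no lower from compound 2 to compound 3 (the limit leaves the size open). None of them has a readable size, so no step beyond the scatter is expected in this assay and no direction can be given. Compound 4 is expected at 50000 nM, with an estimated range from 20000 nM to 70000 nM. The expected step is a number no higher from compound 3 to compound 4 (the limit leaves the size open).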

Compound 4, half-maximal effective concentration: > 50000 nM
Compound 4 gave a limit, no number (the forecaster's own chance of this, stated with the estimate: 60%); the middle value sits exactly at the limit.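

In this assay, among the compounds shown here, the place on the shared core now holds a five-membered aromatic ring with 2 hetero atoms, 1H-pyrazol-4-yl, as well as six-membered aromatic rings of carbon only, and the readings still gather at one point: the limit of > 50000 nM in this assay, at which 3 of the 4 values shown sit. The one step to compound 4 that shows a direction is a number no lower from compound 2 to compound 4 (the limit leaves the size open) and its size stays open. The other steps to compound 4 cannot be read. Going by these compounds, how far compounds 1, 3 and 4 lie past the limit stays open, as does whether an amine or a carboxylic acid at this place would give a reading with a readable size.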